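The source may hold more compounds than are shown below. What is called first, only, known or untested is meant among the compounds shown, and "the series" means these compounds.

For the measured compounds named here, in a functional assay on MKN-45 cells (Homo sapiens) for cytotoxicity (a lower number here means a stronger inhibitor, a higher number a weaker inhibitor), compound 2 `COc1ccc(S(=O)(=O)N2CCc3cccc(N)c32)cc1` gives 1200 nM and holds the highest of the two numbers so far, while compound 1 `COc1ccc(S(=O)(=O)N2CCc3cccc(NC(=O)c4cccs4)c32)cc1` gives 31 nM here. The change to compound 3 `COc1ccc(S(=O)(=O)N2CCc3cccc(NC(=O)c4ccc(C#N)cc4)c32)cc1` is (4-cyanophenyl)carbonyl in place of hydrogen on a nitrogen on an aromatic ring and places (4-cyanophenyl)carbonyl in place of hydrogen on a nitrogen on an aromatic ring. Going by the values given here, only one measured step bears on this, a 39-fold higher number from compound 1 to compound 2 (1.59 log units; beyond the scatter), a large step in which (thiophen-2-yl)carbonyl gave way to hydrogen on that nitrogen. Read in reverse, it points to a large move toward a lower number, though the incoming group is a different one. The expected step is a 20-fold lower number from compound 2 to compound 3 (1.30 log units; beyond the scatter), a little smaller than the measured one. Compound 3 is estimated at 60 nM, with an expected range from 15 nM to 250 nM.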

Compound 3, half-maximal inhibitory concentration: 89 nM
Compound 3: middle estimate off by 1.5-fold (0.17 log units), on the low side, and the stated range covers the measured number.
By their numbers in this assay, from the lowest: compound 1; then compound 3; then compound 2.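

In this assay a second carbonyl group on this nitrogen also lowers the number: (4-cyanophenyl)carbonyl in place of hydrogen gives a 13-fold lower number from compound 2 to compound 3 (1.13 log units; beyond the scatter), so the gain is not confined to the thiophene-bearing group of compound 1. The ring on the carbonyl carbon still counts, though on a smaller scale: 4-cyanophenyl in place of thiophen-2-yl gives a 2.9-fold higher number from compound 1 to compound 3 (0.46 log units; beyond the scatter). No available evidence explains either step. Still open, from the compounds shown here alone, is how a plain phenyl or a small acetyl group would compare on this nitrogen, and whether the nitrile itself contributes to the number of compound 3.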